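Swapping bromo for dimethylamino on the same core

A few compounds are considered here, and "the series" means these few. Any claim that something is new, unique, unknown or untested is made for them only; others in the source may bear on it.

In a functional assay on HeLa cells (Homo sapiens) for cytotoxicity, read by MTT assay, with a stated time of 24 h (a lower number here means a stronger inhibitor, a higher number a weaker inhibitor), compound 1 `C/C(=N\NC(=O)/C(C#N)=C/c1ccccc1)c1c(O)c2ccc(O)cc2oc1=O` gives 15800 nM, compound 2 `COc1ccc(/C=C(\C#N)C(=O)N/N=C(\C)c2c(O)c3ccc(O)cc3oc2=O)cc1` gives 7850 nM, and compound 3 `C/C(=N\NC(=O)/C(C#N)=C/c1ccc(Br)cc1)c1c(O)c2ccc(O)cc2oc1=O` gives 10600 nM. Compound 3 therefore cannot be told apart from either of the others. Compound 4 `C/C(=N\NC(=O)/C(C#N)=C/c1ccc(N(C)C)cc1)c1c(O)c2ccc(O)cc2oc1=O` has dimethylamino in place of bromo on an aromatic carbon. Three measured changes at this same place bear on it. Methoxy in place of hydrogen gave a 2.0-fold lower number from compound 1 to compound 2 (0.30 log units; within the scatter), bromo in place of hydrogen gave a 1.5-fold lower number from compound 1 to compound 3 (0.17 log units; within the scatter), and bromo in place of methoxy gave a 1.4-fold higher number from compound 2 to compound 3 (0.13 log units; within the scatter). As none of these exceeded the scatter, no larger shift is expected here. The expected change is a 1.2-fold lower number from compound 3 to compound 4 (0.07 log units; within the scatter). For compound 4 the estimated value is 9000 nM, with an expected range from 4000 nM to 19000 nM.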

Compound 4, half-maximal inhibitory concentration: 5140 nM
Compound 4: middle estimate off by 1.8-fold (0.24 log units), on the high side, within the range that was stated.
By their numbers in this assay, from the lowest: compounds 4, 2, 3 and 1 (each within the scatter of the next, the first and the last beyond it).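

In this assay, this position gives its first changes beyond the scatter, both modest: dimethylamino in place of bromo (a 2.1-fold lower number from compound 3 to compound 4 (0.31 log units; beyond the scatter)) and in place of hydrogen (a 3.1-fold lower number from compound 1 to compound 4 (0.49 log units; beyond the scatter)). In place of methoxy it stays within the scatter (a 1.5-fold lower number from compound 2 to compound 4 (0.18 log units; within the scatter)), so compound 4 cannot be told apart from compound 2. Nothing measured here explains the shift.

As far as these compounds go, whether the gain needs both methyl groups remains open, as a plain amine would test. A carboxylic acid at this position is also an open case.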